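Swapping a Thiophene for a Pyrazine on a Bicyclic Amine

This account rests on a few compounds, and the source may have more. Where it says the series, first, only, none or still open, it means among the compounds named here.

Of the compounds shown here, two of a shared core have been tested in an ADME assay on MDCK cells (Canis lupus familiaris) for cytotoxicity, read by microscopy, with a stated time of 48 h; on this read-out higher numbers stand for lower toxicity in this test and lower numbers for higher toxicity in this test. Compound 1 `C[C@H]1[C@H](NCc2ccsc2)C[C@H]2C[C@@H]1C2(C)C` carries a thiophen-3-yl group on the saturated chain carbon bound to the amine nitrogen, and in this assay compound 1 gives 50000 nM, the highest of the two numbers. Compound 2 `C[C@H]1[C@H](NCc2sccc2C2CCCCC2)C[C@H]2C[C@@H]1C2(C)C` adds a cyclohexyl ring on its thiophene and gives 1560 nM, a lower number that lies beyond the usual scatter, so compound 2 is the more toxic of the pair.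

Compound 3 `C[C@H]1[C@H](NCc2cnccn2)C[C@H]2C[C@@H]1C2(C)C` differs from compound 1 in one place: pyrazin-2-yl in place of thiophen-3-yl on a saturated chain carbon bound to an amine nitrogen. For the measured compounds named here, nothing among the measured compounds covers this exact exchange, so the expectation rests on compound 1 alone. The step from compound 1 to compound 3 is expected to be no change at the digits printed from compound 1 to compound 3 (within the scatter), that is, no change beyond the scatter. Compound 3 is therefore estimated at 50000 nM, with a range from 20000 nM to 100000 nM.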

Compound 3, minimum cytotoxic concentration: > 100000 nM
Compound 3 was reported as a limit (the forecaster's own chance of this, stated with the estimate: 30%); middle value at least 2.0-fold (0.30 log units) from the limit.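

For the compounds shown here, compound 1 and compound 2 both keep a thiophene, so compound 3 gives the first look at a different aromatic ring at this place. Putting pyrazin-2-yl in place of thiophen-3-yl on a saturated chain carbon bound to an amine nitrogen gives an at least 2.0-fold higher number from compound 1 to compound 3 (0.30 log units; that floor lies within the scatter), so this change brings no sign of higher toxicity in this assay. The reading for compound 3 is a limit and not a number, which leaves only a floor for the size of the step: the limit of > 100000 nM in this assay, at which 1 of the 3 values shown sits.

The compounds shown cannot tell whether the true step reaches beyond the scatter, or whether ring size or the ring nitrogens matter more. A phenyl ring or a pyridin-2-yl ring at this place could help separate those two changes.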